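Branched amine variants on a shared triazolopyrimidine-free core

The compounds below may be only part of what the source reports. "The series", "measured", "known", "first", "only" and "open" are said of these compounds alone.

Measured compounds:
- compound 1 `CCCCC(CC)Nc1nc(C)nc2c1nnn2-c1c(C)cc(C)cc1C`; in an in vitro assay on 293-EBNA cells for binding affinity to corticotropin-releasing factor receptor 1 (Homo sapiens) (a higher number here means a weaker inhibitor, a lower number a stronger inhibitor), compound 1 gives 7.6 nM
- compound 2 `COCC(COC)Nc1nc(C)nc2c1nnn2-c1ccc(C(C)C)cc1Br`; in this assay compound 2 gives 10.3 nM
- compound 3 `CCCCN(CC)c1nc(C)nc2c1nnn2-c1ccc(SC)cc1Br`; in this assay compound 3 gives 10.6 nM

All three numbers lie close together. Compound 2 stands with compound 3 and compound 1 inside the usual scatter of repeated measurements, so the three cannot be separated by potency on these data alone. Going by the values given here, no single-point step between measured compounds is available.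

Compound 4 `CCCCC(CCCC)Nc1nc(C)nc2c1nnn2-c1ccc(C(C)C)cc1Br` has not yet been measured in this assay. It differs from compound 2 by one change: 1-butylpentyl in place of 2-methoxy-1-(methoxymethyl)ethyl on a nitrogen on an aromatic ring. Among the compounds with values here, the measured compounds offer no direct precedent for this exact exchange, but compound 1 carries a branched alkyl on the same nitrogen and gives 7.6 nM, which is no worse than the value of compound 2.

The step from compound 2 to compound 4 is expected to be small, leaning toward a lower number, at a 1.5-fold lower number from compound 2 to compound 4 (0.17 log units; within the scatter). Compound 4 is therefore estimated at 7 nM, with a range from 3 nM to 16 nM.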

Compound 4, inhibition constant: 4.5 nM
Estimate against measurement, compound 4: 1.6-fold (0.19 log units) above, and the stated range covers the measured number.
By their numbers in this assay, from the lowest: compounds 4, 1, 2 and 3 (each within the scatter of the next, the first and the last beyond it).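

In this assay, going by these compounds alone, 1-butylpentyl in place of 2-methoxy-1-(methoxymethyl)ethyl on a nitrogen on an aromatic ring gives a 2.3-fold lower number from compound 2 to compound 4 (0.36 log units; beyond the scatter) and is the first change that can be read at a single place. At this position, a chain of 9 carbon atoms with 0 hydrogen-bond acceptors serves at least as well as a chain with 2 hydrogen-bond acceptors, so the oxygens of the leaving group are not required for a number of this size in this pair. No measurement here bears on why the number falls.

This one step changes chain size and oxygen content together, and a group such as 1-propylbutyl, all carbon with the same heavy-atom count as the leaving group, would separate the two. Also open, on these data alone, is how a ring on the same nitrogen, such as cyclopentyl, would compare with these open chains.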